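Cytotoxicity notes: amide to ester on the shared core

The compounds below may be only part of what the source reports. "The series", "measured", "known", "first", "only" and "open" are said of these compounds alone.

Two members of the series have been run in an ADME assay on L02 cells (Homo sapiens) for cytotoxicity, read by MTT assay, with a stated time of 48 h; a higher number here means a weaker inhibitor, a lower number a stronger inhibitor. Compound 1 `CCN(CC)CCCNC(=O)c1ccc(C(CC)(CC)c2ccc(OCC(=O)C(C)(C)C)c(C)c2)n1CC` gives 2300 nM in this assay. Compound 2 `C#CCNC(=O)c1ccc(C(CC)(CC)c2ccc(OCC(O)C(C)(C)C)c(C)c2)n1CC` gives 4400 nM in this assay; this is the higher of the two numbers, but its gap to compound 1 lies within the scatter, so the two compounds cannot be ordered on these data.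

Compound 3 `CCn1c(C(=O)Oc2ccc(CCO)cc2)ccc1C(CC)(CC)c1ccc(OCC(O)C(C)(C)C)c(C)c1` is not yet measured. It differs from compound 2 at the carbonyl carbon: a group of 10 heavy atoms (8 carbon, 2 oxygen; one six-membered aromatic ring of carbon only) in place of a group of 4 heavy atoms (3 carbon, 1 nitrogen; no ring), on a carbonyl carbon. Among the measured compounds shown here, no measured pair shows what such a change does in this assay, so nothing beyond the scatter is expected in either direction.

For compound 3 the expected step is a 1.1-fold lower number from compound 2 to compound 3 (0.04 log units; within the scatter), not beyond the scatter. Compound 3 is therefore estimated at 4000 nM in this assay, within a range from 1500 nM to 12000 nM.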

Compound 3, half-maximal inhibitory concentration: 22700 nM
Compound 3: middle estimate off by 5.7-fold (0.75 log units), on the low side; measured number outside the range, above it.
By their numbers in this assay, from the lowest: compounds 1 and 2 (each within the scatter of the next); then compound 3.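

At the carbonyl carbon, this assay responds to substitution: swapping propargylamino for the group of 10 heavy atoms with its six-membered aromatic ring of carbon only, which turns the amide into an ester, gives a 5.2-fold higher number from compound 2 to compound 3 (0.71 log units; beyond the scatter) and so a weaker reading beyond the scatter. Compounds 1 and 2 differ in more than one place and could not show this for a single position. No measurement here accounts for the step.

Still open, going by these compounds, is whether the step follows the ester link or the aromatic ring, since the two change together in this one pair. An amide carrying the same aromatic ring, an ester with a plain ethyl chain, or a carboxylic acid on this carbonyl carbon would each bear on that question.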